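A Diastereomer Swap on the Cyclopropane Anilide Core

The source may report more compounds than this note shows. Statements on the series, on what has been measured and on what is new or still open speak of the compounds shown alone.

Compound 1, `CCOC(=O)C1(C(=O)Nc2ccc(F)cc2)CC1c1cc(OC)c(OC)c(OC)c1`: 46700 nM; 42000 nM (2 entries)
Compound 2, `CCOC(=O)[C@]1(C(=O)Nc2ccccc2Cl)C[C@@H]1c1cc(OC)c(OC)c(OC)c1`: > 100000 nM

In a functional assay on SW480 cells (Homo sapiens) for cytotoxicity, read by MTT assay, with a stated time of 48 h (a lower number here means a stronger inhibitor, a higher number a weaker inhibitor), compound 1 gives 46700 nM; 42000 nM (2 entries), repeated entries that agree with one another (the several entries of compound 1 in this assay, 46700 nM; 42000 nM (2 entries)). Compound 2 stands differently in this assay: it reports only a limit, > 100000 nM, and so no number is attached to it (the limit of > 100000 nM in this assay, at which 1 of the 2 values shown sits). Within the data shown here, compound 1 and compound 2 differ in more than one place, so their two values show only that one is a number and the other a limit, and no measured step joins them.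

Compound 3, `CCOC(=O)[C@]1(C(=O)Nc2ccccc2Cl)C[C@H]1c1cc(OC)c(OC)c(OC)c1`, has not yet been measured. It differs from compound 2 in one way: the two compounds have the same atoms and bonds and differ only in configuration as drawn: 1 of 2 stereo elements differ; a stereocentre at a saturated ring carbon is drawn R in compound 2 and S in compound 3. No measured pair here shares that kind of change, so the size of its effect in this assay is not shown. With compound 2 at a limit, a number for compound 3 would itself define the step.

Compound 3 is expected near 70000 nM, within the range 25000 nM to 200000 nM. The expected step is an at least 1.4-fold lower number from compound 2 to compound 3 (0.15 log units; that floor lies within the scatter), with a real chance that this assay again returns only a limit.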

Compound 3, half-maximal inhibitory concentration: 25600 nM
The estimate for compound 3 lay 2.7-fold (0.44 log units) above the measured number; the range from low to high includes it.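

With atoms and bonds unchanged, turning a stereocentre at a saturated ring carbon from R to S gives, in this assay, an at least 3.9-fold lower number from compound 2 to compound 3 (0.59 log units; beyond the scatter). Compound 2 stands at a limit, > 100000 nM, so this step gives only a floor and not a measured size. It is the first step on this core that can be read at all, since compound 1 is joined to no other compound by a single change, and because nothing else separates the pair, the change in value can be put down to that one stereocentre: the fact that compounds 2 and 3 differ only in the configuration as drawn

Compound 1, at 46700 nM; 42000 nM (2 entries), differs from compound 3 in more than one place, so the compounds shown do not tell whether the same change of configuration would have a similar effect with a different anilide, or how the anilide itself contributes. They also leave open the role of the second stereocentre, which stays the same in the pair, and whether a carboxylic acid or a primary amide in place of the ethyl ester would shift the values in this assay.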